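Swapping the thiazole amide for a chlorinated trifluoromethylphenyl

This account rests on a few compounds, and the source may have more. Where it says the series, first, only, none or still open, it means among the compounds named here.

Of the compounds shown here, two sharing one core have been measured in a functional assay on MDA-MB-435 cells (Homo sapiens) for antiproliferative activity, read by MTT assay, with a stated time of 72 h; a lower number here means a stronger inhibitor, a higher number a weaker inhibitor. Compound 1 `Cc1ccc(C(=O)Nc2cccc(C(F)(F)F)c2)cc1C#Cc1nn([C@@H]2CCN(C)C2)c2ncnc(N)c12` gives 44 nM in this assay. Compound 2 `Cc1ccc(NC(=O)c2cnc(C(C)(C)C)s2)cc1C#Cc1nn(C[C@@H](C)CO)c2ncnc(N)c12` gives 73 nM, the higher of the two numbers, yet its gap to compound 1 lies within the scatter, so the two are read as equivalent on this evidence.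

Compound 3 `Cc1ccc(NC(=O)c2ccc(Cl)c(C(F)(F)F)c2)cc1C#Cc1nn(C[C@@H](C)CO)c2ncnc(N)c12` has not yet been measured. It differs from compound 2 in one place: 4-chloro-3-(trifluoromethyl)phenyl in place of 2-(tert-butyl)-1,3-thiazol-5-yl on a carbonyl carbon. Among the measured compounds shown here, no measured pair isolates this exchange, so no computed step is available for it; only the two values above can guide the expectation.

The expected step from compound 2 to compound 3 in this assay is a 1.5-fold lower number from compound 2 to compound 3 (0.16 log units; within the scatter), small and toward a lower number, but not beyond the scatter, because compound 1, whose amide likewise rests on a carbon-only six-membered ring rather than a thiazole, gives 44 nM. On that basis compound 3 is estimated at 50 nM in this assay, with a range from 15 nM to 160 nM.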

Compound 3, half-maximal inhibitory concentration: 319 nM
Compound 3: middle estimate off by 6.4-fold (0.80 log units), on the low side, outside the stated range (above it).
By their numbers in this assay, from the lowest: compounds 1 and 2 (each within the scatter of the next); then compound 3.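

In this assay, among the compounds shown here, the group on this carbonyl carbon is not freely exchangeable: 4-chloro-3-(trifluoromethyl)phenyl in place of 2-(tert-butyl)-1,3-thiazol-5-yl gives a 4.4-fold higher number from compound 2 to compound 3 (0.64 log units; beyond the scatter), the only step here that isolates one place, and it lies beyond the scatter. Compound 1 differs from compound 3 in more than one place, so its carbon-only six-membered ring gives no reading of this exchange, and the step holds only for the shared core and side chain of compound 2 and compound 3. No measurement at hand accounts for the rise in the number with this exchange.

Still open, from the compounds shown here alone, is whether the rise goes with leaving the thiazole ring or with the chlorine, the trifluoromethyl group or the loss of the tert-butyl group, as all of these change together in this one step; a 3-(trifluoromethyl)phenyl without the chlorine, or a plain phenyl, on the same carbonyl carbon would separate them. Also open, going by these compounds, is whether the step keeps its size when the hydroxyl-bearing side chain gives way to an amine or a carboxylic acid.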